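A Chloro-to-Bromo Step on a Shared Core

This account rests on a few compounds, and the source may have more. Where it says the series, first, only, none or still open, it means among the compounds named here.

Of the compounds shown here, three built on one shared core have been tested in a functional assay on HCT-116 cells (Homo sapiens) for inhibition, read by MTT assay, with a stated time of 48 h; a higher number here means a weaker inhibitor, a lower number a stronger inhibitor. Compound 1 `COc1ccc(CNc2cc(OC)c(OC)c(OC)c2)cc1Cl` gives 41700 nM. Compound 3 `COc1ccc(CNc2cc(OC)c(OC)c(OC)c2)cc1Br` gives 48100 nM in this assay. The difference between these two is bromo in place of chloro on an aromatic carbon, and the step it made is a 1.2-fold higher number from compound 1 to compound 3 (0.06 log units; within the scatter). Compound 2 `COc1cc(NCc2ccc(Cl)cc2)cc(OC)c1OC` carries its halogen in another part of the molecule, and how its core differs from the core of compound 1 is not broken down here. In this assay compound 2 reaches only > 80000 nM, which is a limit of the measurement and not a number (the limit of > 80000 nM in this assay, at which 1 of the 3 values shown sits).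

Compound 4 `COc1cc(NCc2ccc(Br)cc2)cc(OC)c1OC` has not yet been measured. Its difference from compound 2 is bromo in place of chloro on an aromatic carbon. This is the same kind of change as that from compound 1 to compound 3, but the place is not the same: in the measured pair the halogen sits ortho to a methoxy group and meta to a large group, whereas in compound 4 it sits para to a large group. Since the measured step of a 1.2-fold higher number from compound 1 to compound 3 (0.06 log units; within the scatter) stays within the scatter, little movement is expected here either. The expected step is a step that the limit leaves unreadable from compound 2 to compound 4, and it rests on the step of a 1.2-fold higher number from compound 1 to compound 3 (0.06 log units; within the scatter). Compound 4 is therefore estimated at about 90000 nM, with a range from 40000 nM to 200000 nM, and most likely the assay will again report only a limit for compound 4.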

Compound 4, half-maximal inhibitory concentration: > 80000 nM
Compound 4 gave a limit, no number; the forecaster's own chance of this, stated with the estimate: 70%; the middle value is on the limit's open side.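

Like compound 2, compound 4 returned a limit and not a number, so no step between compound 2 and compound 4 can be read: the limit of > 80000 nM in this assay, at which 2 of the 4 values shown sit.

The compounds shown leave open whether the change from 4-chlorophenyl to 4-bromophenyl shifts the inhibition of these cells at all, and whether it would stay as small as a 1.2-fold higher number from compound 1 to compound 3 (0.06 log units; within the scatter).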